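The source may report more compounds than this note shows. Statements on the series, on what has been measured and on what is new or still open speak of the compounds shown alone.

Going by the values given here, the two compounds measured so far in an assay on isolated protein for inhibition of histone deacetylase 8 (Homo sapiens), read by fluorescence, with a stated time of 10 min (on this read-out lower numbers stand for stronger inhibition and higher numbers for weaker inhibition), share a chain of the same length that links a hydroxamic acid or an anilide to a heteroaromatic core. Compound 1, `O=C(CCCCCCc1nc(-c2cccnc2)no1)NO`, carries the hydroxamic acid, and in this assay compound 1 gives 1830 nM. Compound 2, `Nc1ccccc1NC(=O)CCCCCCc1nc(-c2ccccc2)no1`, carries the ortho-amino anilide in place of the hydroxamic acid and a phenyl group on the core. For compound 2 this assay reports only a limit, > 10000 nM, and no number; that limit is where compound 2 stands, at the limit of > 10000 nM in this assay, at which 1 of the 2 values shown sits. Among the compounds with values here, nothing beyond the limit is known for compound 2, and no step between compound 2 and any other measured compound can be worked out.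

Compound 3, `Nc1ccccc1NC(=O)CCCCCCc1nc(-c2ccc(C(F)(F)F)cc2)no1`, differs from compound 2 by a single change: trifluoromethyl in place of hydrogen on an aromatic carbon. Since compound 2 sits at a limit, any step from compound 2 to compound 3 is expected to be none beyond the scatter, the estimated step being a step that the limit leaves unreadable from compound 2 to compound 3. For compound 3 the estimate in this assay is 15000 nM, with a range from 5000 nM to 50000 nM, most likely again reported only as a limit.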

Compound 3, half-maximal inhibitory concentration: > 10000 nM
Compound 3 gave a limit, no number; the forecaster's own chance of this, stated with the estimate: 80%; the middle value is on the limit's open side.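

No step can be read from compound 2 to compound 3 in this assay, since each of the two compounds is reported only as a limit and not as a number: the limit of > 10000 nM in this assay, at which 2 of the 3 values shown sit.

The compounds shown leave open how strongly compound 2 and compound 3 each inhibit, and whether trifluoromethyl in place of hydrogen on an aromatic carbon changes that at all.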